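The source may hold more compounds than are shown below. What is called first, only, known or untested is meant among the compounds shown, and "the series" means these compounds.

Values in a functional assay on THP-1 cells (Homo sapiens) for cytotoxicity, read by MTT assay, with a stated time of 72 h; a higher number here means a weaker inhibitor, a lower number a stronger inhibitor:
- Compound 1 `C=C1CC[C@H]2C(C)(C)CCC[C@]2(C)[C@H]1CCC(C)CC(=O)OC`: > 200000 nM (a limit)
- Compound 2 `Cc1ccc(/C=C2\CC[C@H]3C(C)(C)CCC[C@]3(C)[C@H]2CCC(C)CC(=O)O)cc1`: 91000 nM
- Compound 3 `COc1ccc(/C=C2\CC[C@H]3C(C)(C)CCC[C@]3(C)[C@H]2CCC(C)CC(=O)O)cc1OC`: 106000 nM

Going by the values given here, compound 1 carries (the limit of > 200000 nM in this assay, at which 1 of the 3 values shown sits); this is a limit and yields no step.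

Among the compounds with values here, compound 2, at 91000 nM, holds one of only two numbers, and the other lies within the scatter of it. Compound 4 `CC(CC[C@H]1/C(=C/c2ccc(F)cc2)CC[C@H]2C(C)(C)CCC[C@]12C)CC(=O)O` is still unmeasured. Its structural change is fluoro in place of methyl on an aromatic carbon, that is, 4-methylphenyl to 4-fluorophenyl, with fluoro in place of methyl on an aromatic carbon.

Within the data shown here, one measured step bears on this group: a 1.2-fold higher number from compound 2 to compound 3 (0.07 log units; within the scatter), with 3,4-dimethoxyphenyl in place of 4-methylphenyl. That larger exchange stayed within the scatter, so no step beyond the scatter is expected in this assay for the smaller exchange, and no direction can be assigned. The estimated change is a 1.0-fold higher number from compound 2 to compound 4 (0.02 log units; within the scatter). For compound 4 the expected value is 95000 nM, with an estimated range of 55000 nM to 165000 nM.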

Compound 4, half-maximal inhibitory concentration: > 200000 nM
Compound 4 gave a limit, no number (the forecaster's own chance of this, stated with the estimate: 10%); middle value at least 2.1-fold (0.32 log units) away from the limit.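

In this assay, going by these compounds alone, the earlier compounds showed only a 1.2-fold higher number from compound 2 to compound 3 (0.07 log units; within the scatter), so the substituent on this six-membered aromatic ring had not yet been seen to matter. Fluoro in place of methyl on the aromatic carbon para to a large group now gives an at least 2.1-fold higher number from compound 2 to compound 4 (0.34 log units; beyond the scatter), so a single-atom exchange at this position moves the reading beyond the scatter, while the larger exchange to 3,4-dimethoxyphenyl did not. Compound 4 gives a limit, not a number: the limit of > 200000 nM in this assay, at which 2 of the 4 values shown sit.

The other comparison, an at least 1.8-fold higher number from compound 3 to compound 4 (0.27 log units; that floor lies within the scatter), does not by itself separate these two compounds. On these data alone, the true size of the fluoro effect remains open, as does whether chloro, trifluoromethyl or an amine on the same aromatic carbon would give a measurable number in this assay.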